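The source may report more compounds than this note shows. Statements on the series, on what has been measured and on what is new or still open speak of the compounds shown alone.

Compound 2 `O[C@](Cc1ccccc1)(c1ccccc1)[C@@H]1CNCCO1` gives 5.5% in an assay on isolated protein for displacement of a labelled ligand from sodium-dependent dopamine transporter (Homo sapiens), tested at 1000 nM (a higher number here means more inhibition at the concentration tested (going by the name of the read-out), a lower number less inhibition), the second highest of the three numbers measured. Compound 3 `COc1ccc(C[C@@](O)(c2ccccc2)[C@@H]2CNCCO2)cc1` gives 6.2%, and compound 1 `O[C@](Cc1ccccc1-c1ccccc1)(c1ccccc1)[C@@H]1CNCCO1` gives 2.9%; both lie within the scatter of compound 2. Compound 4 `O[C@](Cc1ccccc1Cl)(c1ccccc1)[C@@H]1CNCCO1` differs from compound 2 by chloro in place of hydrogen on an aromatic carbon. Within the data shown here, two measured steps bear on this change: a number 2.6 percentage points higher from compound 1 to compound 2 (within the scatter), which puts hydrogen in place of phenyl on an aromatic carbon, and a number 0.7 percentage points higher from compound 2 to compound 3 (within the scatter), which puts methoxy in place of hydrogen on an aromatic carbon. Neither reaches beyond the scatter, so compound 4 is expected to show no step beyond the scatter either, with a number 0.5 percentage points higher from compound 2 to compound 4 (within the scatter). Compound 4 is therefore estimated at 6%, within a range from 0% to 16%.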

Compound 4, a percentage reported as inhibition, at one concentration (the size of the read-out at that concentration, not a potency): 20.8%
For compound 4 the middle estimate is 14.8 percentage points below the measured one; the whole stated range lies below it.
By their numbers in this assay, from the lowest: compounds 1, 2 and 3 (each within the scatter of the next); then compound 4.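

In this assay, chloro on this aromatic carbon, ortho to a large group, is the change that lifts the number beyond the scatter (a number 15.3 percentage points higher from compound 2 to compound 4 (beyond the scatter)). Phenyl on the same carbon gives no such rise over hydrogen, and chloro stands clearly apart from it (a number 17.9 percentage points higher from compound 1 to compound 4 (beyond the scatter)), so at this carbon the result depends on which group enters. Nothing available accounts for this rise. Open, from the compounds shown here alone, is whether fluoro, bromo, methyl or an amine on this carbon would behave like chloro, and whether chloro elsewhere on the ring would give the same rise.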